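Fluoro for hydrogen on the shared core: expected step

The source may report more compounds than this note shows. Statements on the series, on what has been measured and on what is new or still open speak of the compounds shown alone.

Measured compounds:
compound 1 `O=c1c(C2N=C(c3ccccc3)SS2)coc2cc(Cl)c(Cl)cc12` — in a functional assay on COLO 205 cells (Homo sapiens) for inhibition, read by sulforhodamine B assay, with a stated time of 48 h (a higher number here means a weaker inhibitor, a lower number a stronger inhibitor), this is a limit of the assay, > 100000 nM
compound 2 `O=c1c(C2N=C(c3ccccc3)SS2)coc2cc(Cl)ccc12` — in this assay compound 2 gives 76700 nM

Within the data shown here, compound 2 stands as the only numerical value in this assay; the other value shown is a limit. Among the measured compounds shown here, the one measured step, an at least 1.3-fold lower number from compound 1 to compound 2 (0.11 log units; that floor lies within the scatter), removes a chloro from an aromatic carbon and sits on the floor set by the limit of > 100000 nM in this assay, at which 1 of the 2 values shown sits, so it cannot be read as a real change.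

Compound 3 `O=c1c(C2N=C(c3ccccc3)SS2)coc2cc(Cl)c(F)cc12` differs from compound 2 by fluoro in place of hydrogen on an aromatic carbon. This puts a fluorine on the same aromatic carbon that carries chloro in compound 1 and hydrogen in compound 2. For the measured compounds named here, the only step that bears on it, an at least 1.3-fold lower number from compound 1 to compound 2 (0.11 log units; that floor lies within the scatter), is within the scatter, so no step beyond the scatter is expected in this assay in either direction; a drift toward a weaker number, like compound 1 with its limit of > 100000 nM, is the more likely side.

Compound 3 is therefore estimated at 90000 nM, within 40000 nM to 200000 nM, corresponding to an expected step of a 1.2-fold higher number from compound 2 to compound 3 (0.07 log units; within the scatter).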

Compound 3, half-maximal inhibitory concentration: > 100000 nM
Compound 3 gave a limit, no number; the forecaster's own chance of this, stated with the estimate: 35%; middle value at least 1.1-fold (0.04 log units) away from the limit.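

On this aromatic carbon, ortho to a chloro group, fluoro behaves like chloro in this assay: compound 3, like compound 1, gives a limit and not a number. The step of an at least 1.3-fold higher number from compound 2 to compound 3 (0.11 log units; that floor lies within the scatter) rests on that limit and shows no real change for fluoro in place of hydrogen, and the step for fluoro in place of chloro cannot be read, as both of its ends are limits. Compound 2, with hydrogen at this place, therefore remains the only compound here with a number, and most of the small set sits at the edge of the assay: the limit of > 100000 nM in this assay, at which 2 of the 3 values shown sit.

Going by these compounds, whether any group on this aromatic carbon can give a number clearly lower than that of compound 2, 76700 nM, stays open; an amine, a methoxy group or a nitrile there would each compare directly with compound 2. Equally open, on these data alone, is what a hydroxyl group or a longer chain in place of the chloro group shared by all three compounds would do in this assay.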